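Swapping the aryl group on the hydrazone arm

This account rests on a few compounds, and the source may have more. Where it says the series, first, only, none or still open, it means among the compounds named here.

The measured compounds in a functional assay on MCF7 cells (Homo sapiens) for antiproliferative activity, read by MTT assay, with a stated time of 72 h; on this read-out higher numbers stand for weaker inhibition and lower numbers for stronger inhibition:
compound 1 `CCCSc1nc(N/N=C/c2cccs2)c2nnn(Cc3ccccc3)c2n1` gives > 64000 nM, which is a limit of the assay rather than a number.
compound 2 `CCCSc1nc(N/N=C/c2c[nH]c3ccccc23)c2nnn(Cc3ccccc3)c2n1` gives 9010 nM.
compound 3 `CCCSc1nc(N/N=C/c2ccc(Br)cc2)c2nnn(Cc3ccccc3)c2n1` gives > 64000 nM, again a limit of the assay.

Compound 3 therefore stands at the upper edge of what this assay can report, sharing that position with compound 1, as the limit of > 64000 nM in this assay, at which 2 of the 3 values shown sit, records. Among the measured compounds shown here, the only numbered value belongs to compound 2, and the step of an at least 7.1-fold higher number from compound 2 to compound 3 (0.85 log units; beyond the scatter) shows how far compound 3 falls behind it; the step of an at least 7.1-fold lower number from compound 1 to compound 2 (0.85 log units; beyond the scatter) tells the same story from the other side, while a step that the two limits leave unreadable from compound 1 to compound 3 cannot be sized because both ends are limits.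

Compound 4 `CCCSc1nc(N/N=C/c2c(O)ccc3ccccc23)c2nnn(Cc3ccccc3)c2n1` is made from compound 3 by the change (2-hydroxynaphthalen-1-yl in place of 4-bromophenyl on a carbon with a double bond to nitrogen). For the measured compounds named here, the closest precedent is compound 2, where a group with two fused rings and one hydrogen-bond donor was paired with a measurable value, whereas the single-ring groups of compound 1 and compound 3 were not. On that basis the expectation for compound 4 is a value in the region of compound 2, meaning the step of an at least 4.2-fold lower number from compound 3 to compound 4 (0.63 log units; beyond the scatter) is expected to bring the number back into the measurable range. The estimate for compound 4 in this assay is 15000 nM, expected to lie between 4000 nM and 64000 nM.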

Compound 4, half-maximal inhibitory concentration: 6400 nM
For compound 4 the middle estimate is 2.3-fold (0.37 log units) above the measured one; the measured number falls inside the stated range.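

In this assay, the 2-hydroxynaphthalen-1-yl group of compound 4 gives a second numbered value on the hydrazone arm, so a measurable result at this carbon is no longer tied to the 1H-indol-3-yl group alone. Against the two single-ring groups the change is large, with an at least 10-fold lower number from compound 3 to compound 4 (1.00 log units; beyond the scatter) and an at least 10-fold lower number from compound 1 to compound 4 (1.00 log units; beyond the scatter), while the two groups with fused rings cannot be told apart, with a 1.4-fold lower number from compound 2 to compound 4 (0.15 log units; within the scatter). Among these compounds, then, both groups with fused rings give a number and both single-ring groups stay at a limit of the assay, which is not a number: the limit of > 64000 nM in this assay, at which 2 of the 4 values shown sit.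

As far as these compounds go, compound 4 differs from compound 3 in both its ring count and its hydroxyl group, so it remains open which of the two goes with the measurable value; a plain naphthyl group or a hydroxyphenyl group in the same place would separate them. Also open, from the compounds shown here alone, is how a group carrying an amine or a carboxylic acid would read on this carbon, and whether any group here can bring the number far below those of compound 2 and compound 4.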